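Two Bis(trifluoromethyl)benzenesulfonamides and a Dimethoxybenzyl Analogue

This account rests on a few compounds, and the source may have more. Where it says the series, first, only, none or still open, it means among the compounds named here.

Measured compounds:
- compound 1, `CC(C)(C)c1ccc(CNCCCNS(=O)(=O)c2cc(C(F)(F)F)cc(C(F)(F)F)c2)cc1`: 2500 nM
- compound 2, `O=S(=O)(NCCCCNCc1ccc(Br)cc1)c1cc(C(F)(F)F)cc(C(F)(F)F)c1`: 2200 nM

The two compounds share a core carrying a bis(trifluoromethyl)phenyl sulfonamide joined through a saturated chain to a secondary amine bearing a benzyl group. In a functional assay on PANC-1 cells (Homo sapiens) for inhibition, read by MTT assay, with a stated time of 72 h (on this read-out higher numbers stand for weaker inhibition of growth and lower numbers for stronger inhibition of growth), compound 1 gives 2500 nM, and compound 2 gives 2200 nM in this assay. The two numbers lie within the usual scatter of each other, so compound 1 cannot be separated from compound 2 on these data.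

Compound 3, `COc1ccc(CNCCCNS(=O)(=O)c2cc(C(F)(F)F)cc(C(F)(F)F)c2)cc1OC`, has not yet been measured. It differs from compound 1 in one place: 3,4-dimethoxyphenyl in place of 4-(tert-butyl)phenyl on a saturated chain carbon bound to an amine nitrogen. For the measured compounds named here, no pair of measured compounds shows this change, and no step between measured compounds is known, so the size of this step cannot be read from the data. Going by the values given here, because compound 1 gives 2500 nM and compound 2 gives 2200 nM, the series so far sits in the low-micromolar range, and compound 3 is expected to remain near it, with a step of a 1.4-fold higher number from compound 1 to compound 3 (0.15 log units; within the scatter) expected to be small, possibly within the scatter. For compound 3 the estimated value in this assay is 3500 nM, with a range from 1200 nM to 12000 nM.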

Compound 3, concentration for 50% growth inhibition: 18000 nM
Beside the measured number, compound 3's estimate is 5.1-fold (0.71 log units) below it; measured number above the stated range.
By their numbers in this assay, from the lowest: compounds 2 and 1 (each within the scatter of the next); then compound 3.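

In this assay, the group on the saturated chain carbon bound to an amine nitrogen turns out to matter: 3,4-dimethoxyphenyl in place of 4-(tert-butyl)phenyl gives a 7.2-fold higher number from compound 1 to compound 3 (0.86 log units; beyond the scatter), which here means weaker inhibition of growth. The earlier pair could not show this, as compound 1 and compound 2 differ in more than one place and their values lie within the scatter of each other, whereas this single change separates two compounds clearly, even though the groups that leave and enter both have 10 heavy atoms and one six-membered aromatic ring, and only the entering group has hydrogen-bond acceptors. The data available here offer no measurement that explains the size of this step.

As far as these compounds go, it remains open whether a single methoxy group, a hydroxyl group or a trifluoromethyl group on this ring would give a value closer to that of compound 1 or to that of compound 3. From the compounds shown here alone, it is also open whether the same exchange would have a similar effect on the chain of compound 2.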